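A few compounds are considered here, and "the series" means these few. Any claim that something is new, unique, unknown or untested is made for them only; others in the source may bear on it.

In an ADME assay on Vero cells (Chlorocebus sabaeus) for cytotoxicity, with a stated time of 72 h (a higher number here means a weaker inhibitor, a lower number a stronger inhibitor), compound 1 (`CCOC(=O)c1cc(/C=C/c2cccc(C(C)C)c2)on1`) gives > 128000 nM as a limit, not a number. Compound 2 (`CCOC(=O)c1cc(/C=C/c2cccc([N+](=O)[O-])c2)on1`) gives > 128000 nM which is also a limit. Compound 3 (`CCOC(=O)c1cc(/C=C/c2cccc(N)c2)on1`) stands at > 128000 nM which is again only a limit. Among the measured compounds shown here, the series so far shows the limit of > 128000 nM in this assay, at which 3 of the 3 values shown sit, and no readable number.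

Compound 4 (`CCOC(=O)c1cc(/C=C/c2cccc(O)c2)on1`) has hydroxy in place of amino on an aromatic carbon, meta to a large group: hydroxy in place of amino on an aromatic carbon and nothing else changes. The measured steps that bear on this are a step that the two limits leave unreadable from compound 1 to compound 2 and a step that the two limits leave unreadable from compound 1 to compound 3 and a step that the two limits leave unreadable from compound 2 to compound 3 so none of them offers a size to carry over.

The expected step is a step that the limit leaves unreadable from compound 3 to compound 4 and nothing beyond the scatter is expected in this assay for this change. Compound 4 is estimated at 150000 nM with an expected range from 60000 nM to 300000 nM in this reading.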

Compound 4, half-maximal inhibitory concentration: > 128000 nM
Compound 4: only a limit was reported; the forecaster's own chance of this, stated with the estimate: 85%; the middle value is on the limit's open side.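

No step can be read between compound 4 and compound 1, compound 2 or compound 3 in this assay, each value being only a limit: the limit of > 128000 nM in this assay, at which 4 of the 4 values shown sit.

The compounds shown leave open what readable value, if any, any of these four would give in this assay, and so whether swapping these groups changes it.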